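The source may hold more compounds than are shown below. What is called first, only, known or untested is meant among the compounds shown, and "the series" means these compounds.

Of the compounds shown here, three have been tested in an ADME assay on L6 cells (Rattus norvegicus) for cytotoxicity, read by resazurin assay; on this read-out lower numbers stand for stronger inhibition and higher numbers for weaker inhibition. Compound 1 `N=C(N)c1ccc2[nH]c(Nc3ccccc3)nc2c1` gives 237000 nM in this assay. Compound 2 `N=C(N)c1ccc2[nH]c(Nc3ccc(Cl)c(Cl)c3)nc2c1` gives 39100 nM in this assay, the lowest of the three numbers; compound 3 `N=C(N)c1ccc(Nc2nc3cc(C(F)(F)F)ccc3[nH]2)cc1` gives 41400 nM in this assay, which lies within the usual scatter of the number for compound 2. Only compound 1 stands clearly apart from compound 2, with a gap beyond the scatter.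

Compound 4 `N=C(N)c1ccc2[nH]c(Nc3ccc(Cl)cc3)nc2c1` differs from compound 2 in one place: hydrogen in place of chloro on an aromatic carbon. Among the compounds with values here, no pair among the measured compounds shows this change alone, so the step has to be estimated. Compound 4 is expected to move back toward compound 1, so the step in this assay a 2.3-fold higher number from compound 2 to compound 4 (0.36 log units; beyond the scatter) is expected to raise the number, near the edge of the scatter. The estimate for compound 4 is 90000 nM, with a range from 35000 nM to 220000 nM.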

Compound 4, half-maximal inhibitory concentration: 41600 nM
Estimate against measurement, compound 4: 2.2-fold (0.34 log units) above; the measured number falls inside the stated range.
By their numbers in this assay, from the lowest: compounds 2, 3 and 4 (each within the scatter of the next); then compound 1.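

Replacing with hydrogen the chloro group that sits ortho to a chloro group and meta to a large group gives a 1.1-fold higher number from compound 2 to compound 4 (0.03 log units; within the scatter), so in this assay this second chloro makes no measurable difference. Within the data shown here, the single chloro of compound 4 already accounts for the clear change, with chloro in place of hydrogen giving a 5.7-fold lower number from compound 1 to compound 4 (0.76 log units; beyond the scatter). Nothing measured here explains why one chloro matters and the second does not.

From the compounds shown here alone, it remains open whether an amine or a methoxy group at this position would also leave the number unchanged. It is also unknown whether a lone chloro meta to the large group would give the same step as the chloro in compound 4.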